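The source may report more compounds than this note shows. Statements on the series, on what has been measured and on what is new or still open speak of the compounds shown alone.

Measured compounds in a functional assay on HCT-15 cells (Homo sapiens) for cytotoxicity, read by sulforhodamine B assay, tested at 10 uM; a higher number here means more inhibition at the concentration tested (going by the name of the read-out), a lower number less inhibition:

Compound 1 `CC(=O)OC[C@H]1O[C@@H](n2cc(-c3cc(-c4ccc(C(C)(C)C)cc4)no3)c(=O)[nH]c2=O)C[C@@H]1OC(C)=O` gives 53.8% in this assay.
Compound 2 `CC(=O)OC[C@H]1O[C@@H](n2cc(-c3cc(-c4ccccc4)no3)c(=O)[nH]c2=O)C[C@@H]1OC(C)=O` gives 92.2% in this assay.
Compound 3 `CC(=O)OC[C@H]1O[C@@H](n2cc(-c3cn(Cc4ccccc4)nn3)c(=O)[nH]c2=O)C[C@@H]1OC(C)=O` gives 92.3% in this assay.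

Compound 2 and compound 1 share a core and differ in one place: tert-butyl in place of hydrogen on an aromatic carbon. That change gave a number 38.4 percentage points lower from compound 2 to compound 1 (beyond the scatter), a large loss at the concentration tested.

Compound 3 carries a different core from compound 2; the difference between the two cores is not broken down here. The values of compound 2 and compound 3 lie within the scatter of each other, so no order between them is claimed.

Compound 4 `CC(=O)OC[C@H]1O[C@@H](n2cc(-c3cn(Cc4ccc(C(C)(C)C)cc4)nn3)c(=O)[nH]c2=O)C[C@@H]1OC(C)=O` is not yet measured. It stands to compound 3 as compound 1 stands to compound 2: tert-butyl in place of hydrogen on an aromatic carbon. The place of the change reads the same in both pairs, so this is the same change carried onto the other core. This change occurs twice among the compounds shown, and only one of its steps is measured.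

Within the data shown here, for compound 4 in this assay a step of a number 37.3 percentage points lower from compound 3 to compound 4 (beyond the scatter) is expected, resting on the single measured step of a number 38.4 percentage points lower from compound 2 to compound 1 (beyond the scatter) and on the starting point of compound 3 at 92.3%. Compound 4 is therefore estimated at 55%, with a range from 30% to 80%; the range is wide since the change was measured once only.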

Compound 4, a percentage reported as inhibition, at one concentration (the size of the read-out at that concentration, not a potency): 94.2%
Estimate against measurement, compound 4: 39.2 percentage points below, outside the stated range (above it).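

In this assay, tert-butyl in place of hydrogen on an aromatic carbon gives a step of a number 1.9 percentage points higher from compound 3 to compound 4 (within the scatter), so the large loss seen on the core of compound 2 does not carry over to the core of compound 3: the same change on two cores in this assay, a number 38.4 percentage points lower (beyond the scatter) from compound 2 to compound 1 and a number 1.9 percentage points higher (within the scatter) from compound 3 to compound 4, 40.3 percentage points apart, beyond the scatter of two such steps

In this series, the result of this change therefore cannot be carried from one core to the other, and compound 4 gives no sign of the loss seen in compound 1. The two steps do not show which difference between the cores separates them, or why, and they rest on one pair per core at a single concentration, so they say nothing about potency.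

Open, from the compounds shown here alone, is whether methyl, an amine or a carboxylic acid at the same place would follow the step on the core of compound 2 or the step on the core of compound 3. Also open, going by these compounds, is whether the split between the cores would hold with free hydroxyl groups in place of the two acetyl esters.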